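Trimming the selenium substituent from benzyl to methyl

The source may report more compounds than this note shows. Statements on the series, on what has been measured and on what is new or still open speak of the compounds shown alone.

Of the compounds shown here, two have been measured in a functional assay on PC-3 cells (Homo sapiens) for cytotoxicity, read by MTT assay, with a stated time of 72 h (on this read-out lower numbers stand for stronger inhibition of growth and higher numbers for weaker inhibition of growth), so far. Compound 1, with the structure `CS/C(=N\C(=O)c1sccc1Cl)NC(=O)c1sccc1Cl`, gives 24700 nM in this assay. Compound 2, with the structure `O=C(/N=C(/NC(=O)c1cc(-c2ccccc2)nc2ccccc12)[Se]Cc1ccccc1)c1cc(-c2ccccc2)nc2ccccc12`, gives 39300 nM in this assay, which is the higher of the two numbers; the gap to compound 1 is, however, within the usual scatter of repeated measurements, so the two cannot be placed in order on these figures alone.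

Compound 3, with the structure `C[Se]/C(=N\C(=O)c1cc(-c2ccccc2)nc2ccccc12)NC(=O)c1cc(-c2ccccc2)nc2ccccc12`, has not yet been measured in this assay. It differs from compound 2 in one place: hydrogen in place of phenyl on a saturated chain carbon bound to a selenium atom. Among the compounds with values here, no measured pair here isolates this particular change, and compound 1 differs from both in its acyl groups as well, so it cannot serve as a guide for the step.

With nothing in the data to point either way, the expected step in this assay from compound 2 to compound 3 is a 1.1-fold lower number from compound 2 to compound 3 (0.05 log units; within the scatter), a change no larger than the scatter. Compound 3 is therefore estimated to give 35000 nM in this assay, with a range from 12000 nM to 100000 nM.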

Compound 3, concentration for 50% growth inhibition: 3970 nM
Estimate against measurement, compound 3: 8.8-fold (0.95 log units) above; the measured number lies below the stated range.
By their numbers in this assay, from the lowest: compound 3; then compounds 1 and 2 (each within the scatter of the next).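

Until now the group on selenium could not be judged alone, since compound 1 differs from the other two in its acyl groups as well; compound 2 and compound 3 differ in that one place only. In this assay, trimming benzyl to methyl gives a 9.9-fold lower number from compound 2 to compound 3 (1.00 log units; beyond the scatter), a step beyond the scatter and towards stronger inhibition of growth, so the group on this saturated chain carbon bound to a selenium atom clearly matters in this series, and losing the phenyl with its 6 heavy atoms does not cost activity here. Nothing available explains why this step is so large.

On these data alone, this is a single step, so it remains open whether the smallest group is the best one or whether ethyl or a longer chain of plain carbon would do as well, and whether a chain ending in an amine or a carboxylic acid would be tolerated at this place. As far as these compounds go, it is also open whether the same trimming would give a similar step on a different shared core.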